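The source may hold more compounds than are shown below. What is called first, only, known or untested is meant among the compounds shown, and "the series" means these compounds.

Measured in a functional assay on A549 cells (Homo sapiens) for antiproliferative activity, read by MTT assay, with a stated time of 48 h; on this read-out higher numbers stand for weaker inhibition and lower numbers for stronger inhibition:
- Compound 1 `O=C(/C=C/c1ccccc1)Nc1cc2c(Nc3ccc(F)c(Cl)c3)ncnc2s1`: 11200 nM
- Compound 2 `O=C(/C=C/c1ccccc1)Nc1cc2c(Nc3ccc(Cl)c(Cl)c3)ncnc2s1`: 7600 nM
- Compound 3 `O=C(/C=C/c1ccccc1)Nc1cc2c(Nc3cccc(Cl)c3F)ncnc2s1`: 26200 nM

Compound 3 has the highest number of the three in this assay, and so it is the weakest of them. Its gaps to the other two lie beyond the scatter, but they are modest: a 2.3-fold higher number from compound 1 to compound 3 (0.37 log units; beyond the scatter) and a 3.4-fold higher number from compound 2 to compound 3 (0.54 log units; beyond the scatter). Compound 4 `C#Cc1cccc(Nc2ncnc3sc(NC(=O)/C=C/c4ccccc4)cc23)c1` keeps the shared core and the amide side chain of compound 3 and differs only in the group on the nitrogen on an aromatic ring: 3-ethynylphenyl in place of 3-chloro-2-fluorophenyl on a nitrogen on an aromatic ring. Going by the values given here, none of the measured compounds carries the 3-ethynylphenyl group, so its contribution has not been observed directly. The two steps above alter the same place as this change. That is all that ties them to it. The third, a 1.5-fold lower number from compound 1 to compound 2 (0.17 log units; within the scatter), shows that the swap it records made no difference beyond the scatter. On this evidence, replacing the 3-chloro-2-fluorophenyl group is expected to give a modest shift towards a lower number, comparable in size to those steps, though the direction is uncertain. The expected change is a 2.0-fold lower number from compound 3 to compound 4 (0.30 log units; within the scatter). For compound 4 the estimated value is 13000 nM, with an expected range of 5000 nM to 32000 nM.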

Compound 4, half-maximal inhibitory concentration: 10100 nM
Compound 4: the middle estimate sits 1.3-fold (0.11 log units) above what was measured, and the stated range covers the measured number.
By their numbers in this assay, from the lowest: compounds 2, 4 and 1 (each within the scatter of the next); then compound 3.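

In this assay, going by these compounds alone, the 3-ethynylphenyl group on the nitrogen gives a 2.6-fold lower number from compound 3 to compound 4 (0.41 log units; beyond the scatter), which settles for this pair the direction that the earlier steps left uncertain and shows that this place accepts a group with a triple bond and no halogen. The new group also does not separate from the two halogenated groups that share the place, with a 1.1-fold lower number from compound 1 to compound 4 (0.04 log units; within the scatter) and a 1.3-fold higher number from compound 2 to compound 4 (0.12 log units; within the scatter), so compounds 1, 2 and 4 form one cluster and, among these four compounds, only the 3-chloro-2-fluorophenyl group of compound 3 stands apart. Nothing available offers an account of why these three different groups give such similar numbers or why compound 3 does not join them.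

The compounds shown leave open whether the ethynyl group itself matters, since a nitrile, an amine or a longer alkyne chain in its place would test that directly. They also leave open whether any group on this nitrogen can bring the number clearly below the cluster, or whether the cluster marks the limit of what changes here can do while the amide side chain stays the same.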